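Compound 1 to compound 4: methyl added on a chain carbon

The compounds below may be only part of what the source reports. "The series", "measured", "known", "first", "only" and "open" are said of these compounds alone.

Compound 1 `CCOc1ccc(C(=O)/C=C/c2ccc(C)cc2)cc1` is the anchor of this small set. Within the data shown here, in an assay on isolated protein for inhibition of Amine oxidase [flavin-containing] B (Homo sapiens) (a lower number here means a stronger inhibitor, a higher number a weaker inhibitor), compound 1 gives 210 nM, the only value here that is a number rather than a limit. Compound 2 `O=C(/C=C/c1ccc(ON=C2CCCCC2)cc1)c1ccc(F)cc1` gives < 50 nM in this assay, which is a limit of the assay and not a number; it stands at the limit of < 50 nM in this assay, at which 1 of the 3 values shown sits. Compound 3 `O=C(/C=C/c1cccc(F)c1)c1ccc(-n2ccnc2)cc1` gives > 10000 nM in this assay, again a limit and not a number; it stands at the limit of > 10000 nM in this assay, at which 1 of the 3 values shown sits. Among the measured compounds shown here, since neither of the other two compounds yields a number, compound 1 cannot be ranked against them beyond the fact that its value sits between the two limits, and no pair of measured compounds differs in a single place, so no measured step is available to calibrate from.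

Compound 4 `CCOc1ccc(C(=O)/C=C/c2ccc(CC)cc2)cc1` has not yet been measured. It differs from compound 1 in one place: methyl in place of hydrogen on a saturated chain carbon bound to an aromatic carbon. For a change of this size, one added carbon on a saturated chain, the step from compound 1 to compound 4 is expected to be a 1.0-fold higher number from compound 1 to compound 4 (0.02 log units; within the scatter), which is not expected to fall beyond the usual scatter in either direction. Compound 4 is therefore expected to give 220 nM in this assay, with a range from 70 nM to 700 nM.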

Compound 4, half-maximal inhibitory concentration: 210 nM
Beside the measured number, compound 4's estimate is 1.0-fold (0.02 log units) above it; low and high end bracket the measured number.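

In this assay, among these compounds, the first single-place step reads no change at the digits printed from compound 1 to compound 4 (within the scatter), for methyl in place of hydrogen on a saturated chain carbon bound to an aromatic carbon, the same difference as methyl to ethyl. Compound 2 and compound 3 differ from compound 1 in more than one place and could not isolate this position; the new pair shows that, with the rest of the core of compound 1 held fixed, ethyl and methyl here cannot be told apart in this assay. Neither of the two assay limits on record, those of compound 2 and compound 3, bears on this step, and the data offer no explanation for it.

As far as these compounds go, whether the same reading holds for a longer chain such as propyl or butyl, for a branched isopropyl, or for a chain ending in a primary amine or a carboxylic acid remains open. One step at one place also leaves open whether an added carbon elsewhere on the core of compound 1 would read the same way.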